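Isopropoxy for chloro: expected step for compound 4

This account rests on a few compounds, and the source may have more. Where it says the series, first, only, none or still open, it means among the compounds named here.

In an assay on cells for inhibition of MAP kinase-interacting serine/threonine-protein kinase 1 (Homo sapiens), read by mobility shift assay, with stated times of 10 min and 60 min, in the presence of a further agent that is not named here (on this read-out lower numbers stand for stronger inhibition and higher numbers for weaker inhibition), compound 3 `NC(=O)c1ccc(-c2cccnc2)cc1Cl` gives 11000 nM, the second highest of the three numbers. Compound 2 `Cc1cc(-c2cccnc2)ccc1C(N)=O` gives 22000 nM, and the step of a 2.0-fold lower number from compound 2 to compound 3 (0.30 log units; within the scatter) stays within the scatter; compound 1 `CCOc1cc(-c2cccnc2)ccc1C(N)=O` gives 2200 nM, and the step of a 5.0-fold higher number from compound 1 to compound 3 (0.70 log units; beyond the scatter) lies beyond it. Compound 4 `CC(C)Oc1cc(-c2cccnc2)ccc1C(N)=O` carries the change (isopropoxy in place of chloro on an aromatic carbon). For the measured compounds named here, the step that bears on it is the one from compound 1 to compound 3, an alkoxy group against chloro at the same place, and a 10-fold higher number from compound 1 to compound 2 (1.00 log units; beyond the scatter) points the same way for methyl; run backwards, with an alkoxy group entering for chloro, this suggests a lower number. The expected value for compound 4 is 2500 nM, range 900 nM to 8000 nM. The expected step is a 4.4-fold lower number from compound 3 to compound 4 (0.64 log units; beyond the scatter).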

Compound 4, half-maximal inhibitory concentration: 880 nM
Estimate against measurement, compound 4: 2.8-fold (0.45 log units) above; measured number below the stated range.
By their numbers in this assay, from the lowest: compound 4; then compound 1; then compounds 3 and 2 (each within the scatter of the next).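

In this assay, the gain from an alkoxy group ortho to a carbamoyl group now extends beyond ethoxy: isopropoxy gives a 13-fold lower number from compound 3 to compound 4 (1.10 log units; beyond the scatter) and a 25-fold lower number from compound 2 to compound 4 (1.40 log units; beyond the scatter). Branching the alkoxy group adds a further, modest gain, with a 2.5-fold lower number from compound 1 to compound 4 (0.40 log units; beyond the scatter), so ethoxy does not mark the limit at this position. No measurement shown accounts for these steps.

The compounds shown leave open whether a methoxy group, a longer chain such as butoxy, or a cyclopropylmethoxy group would extend this trend. They also leave open whether an amine at this position would keep the gain.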